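The source may hold more compounds than are shown below. What is called first, only, known or untested is meant among the compounds shown, and "the series" means these compounds.

Among the measured compounds shown here, compound 1 `CCOC(=O)c1cnc(-c2cccs2)nc1NN1C(=O)C=C(C)C1=O` is one of two compounds measured in a functional assay on Jurkat cells for inhibition of nuclear factor NF-kappa-B complex (Homo sapiens); on this read-out higher numbers stand for weaker inhibition and lower numbers for stronger inhibition. Compound 1 gives 20 nM, the lower of the two numbers, while compound 2 `CCOC(=O)c1cnc(S(=O)(=O)c2ccccc2)nc1NN1C(=O)C=C(C)C1=O` gives 10000 nM. For the measured compounds named here, the only measured step, a 500-fold higher number from compound 1 to compound 2 (2.70 log units; beyond the scatter), concerns a change on a different carbon of the shared core and is large. Compound 3 `CC1=CC(=O)N(Nc2nc(-c3cccs3)ncc2C#N)C1=O` differs from compound 1 in another way: cyano in place of ethoxycarbonyl on an aromatic carbon. Going by the values given here, no measured pair shows this exchange, and the step between compound 1 and compound 2 touches a different group, so it cannot be carried over to the present change. For the exchange of ethoxycarbonyl against cyano the data offer no guide beyond compound 1 itself. The expected step is therefore a 2.0-fold higher number from compound 1 to compound 3 (0.30 log units; within the scatter), modest in size, with a wide range allowed for. Compound 3 is estimated at 40 nM, expected to fall between 8 nM and 200 nM.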

Compound 3, half-maximal inhibitory concentration: 5000 nM
Beside the measured number, compound 3's estimate is 130-fold (2.10 log units) below it, and the stated range ends below it.
By their numbers in this assay, from the lowest: compound 1; then compounds 3 and 2 (each within the scatter of the next).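

In this assay, the position on the aromatic carbon para to the thiophen-2-yl group proves highly sensitive to the group it carries: a 250-fold higher number from compound 1 to compound 3 (2.40 log units; beyond the scatter) follows when cyano replaces ethoxycarbonyl. The earlier pair showed a large change only where the thiophen-2-yl group itself was exchanged, with a 500-fold higher number from compound 1 to compound 2 (2.70 log units; beyond the scatter) as its result, so the low number of compound 1 now depends on the groups at both places. No measurement available here accounts for the loss seen with cyano.

The compounds shown leave open whether compound 1 needs the whole ethoxycarbonyl group or only part of it, a question that a carboxylic acid, a methyl ester or a primary amide on this carbon would address. They also leave open how a longer ester chain would read in this assay.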